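This account rests on a few compounds, and the source may have more. Where it says the series, first, only, none or still open, it means among the compounds named here.

Three compounds that share one core and differ only in the aromatic group on a nitrogen have been measured in a functional assay on NCI-N87 cells (Homo sapiens) for antiproliferative activity; a lower number here means a stronger inhibitor, a higher number a weaker inhibitor. Compound 1 (`C#Cc1cccc(Nc2ncnn3ccc(CN4CCC(N)CC4)c23)c1`) gives 120 nM, compound 2 (`NC1CCN(Cc2ccn3ncnc(Nc4ccccc4)c23)CC1`) gives 140 nM and compound 3 (`Cc1ccccc1Nc1ncnn2ccc(CN3CCC(N)CC3)c12`) gives 3300 nM. Compound 2, with a plain phenyl, cannot be told apart from compound 1, and both lie far on the stronger side of compound 3.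

Compound 4 (`COc1ccc(Nc2ncnn3ccc(CN4CCC(N)CC4)c23)cc1Cl`) is compound 2 with a single change: 3-chloro-4-methoxyphenyl in place of phenyl on a nitrogen on an aromatic ring. In words, 3-chloro-4-methoxyphenyl stands in place of phenyl. Two kinds of measured step offer a guide. Putting hydrogen in place of ethynyl barely registers, a 1.2-fold higher number from compound 1 to compound 2 (0.07 log units; within the scatter). Putting methyl in place of hydrogen costs a great deal, a 24-fold higher number from compound 2 to compound 3 (1.37 log units; beyond the scatter), and the step of a 28-fold higher number from compound 1 to compound 3 (1.44 log units; beyond the scatter) is of similar size.

The entering group resembles the 3-ethynylphenyl of compound 1, with its 120 nM, in carrying a group numbered 3, and it has none numbered 2 like compound 3. Among the compounds with values here, no measured compound carries chloro or methoxy, so this guide is weak, and the range must stay wide.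

No step beyond the scatter is expected in this assay, and the estimate is a 1.2-fold lower number from compound 2 to compound 4 (0.07 log units; within the scatter). For compound 4 the estimated value is 120 nM, with an expected range of 30 nM to 500 nM.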

Compound 4, half-maximal inhibitory concentration: 1210 nM
Beside the measured number, compound 4's estimate is 10-fold (1.00 log units) below it; the measured number lies above the stated range.
By their numbers in this assay, from the lowest: compounds 1 and 2 (each within the scatter of the next); then compound 4; then compound 3.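

In this assay, the aromatic group on the nitrogen turns out to be sensitive to more than the 2-methylphenyl of compound 3: putting 3-chloro-4-methoxyphenyl in place of phenyl gives an 8.6-fold higher number from compound 2 to compound 4 (0.94 log units; beyond the scatter), so a ring with no group numbered 2 can also lose activity. Having a group numbered 3 does not by itself keep the number low either, since replacing 3-ethynylphenyl with 3-chloro-4-methoxyphenyl gives a 10-fold higher number from compound 1 to compound 4 (1.00 log units; beyond the scatter). The new group is still not the worst one seen at this position, as replacing 2-methylphenyl with it gives a 2.7-fold lower number from compound 3 to compound 4 (0.44 log units; beyond the scatter), which places compound 4 at an intermediate level; no measurement here accounts for these differences.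

Chloro and methoxy enter together in compound 4, so the compounds shown leave open which of the two carries the loss, or whether it takes both; 3-chlorophenyl and 4-methoxyphenyl would separate them. Also open, on these data alone, is how a phenyl carrying an amine or a carboxylic acid would fare on this nitrogen.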